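One Chlorine Fewer: What to Expect for Compound 4

The source may hold more compounds than are shown below. What is called first, only, known or untested is meant among the compounds shown, and "the series" means these compounds.

Of the compounds shown here, three sharing one core have been measured in a functional assay on PC-3 cells (Homo sapiens) for inhibition, read by sulforhodamine B assay, with a stated time of 48 h; a lower number here means a stronger inhibitor, a higher number a weaker inhibitor. Compound 1 `O=c1c(C(=S)Nc2ccccc2)coc2cc(Cl)ccc12` gives 90800 nM in this assay. Compound 2 `O=c1c(C2N=C(c3ccccc3)SS2)coc2ccc(Cl)cc12` gives 52700 nM, and compound 3 `O=c1c(C2N=C(c3ccccc3)SS2)coc2cc(Cl)c(Cl)cc12` gives 60000 nM. Compound 3 thus sits close to both of its neighbours: its number differs from that of compound 2 only within the scatter, and from that of compound 1 likewise within the scatter, so none of the three can be called stronger or weaker than another.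

Compound 4 `O=c1c(C2N=C(c3ccccc3)SS2)coc2cc(Cl)ccc12` differs from compound 3 by hydrogen in place of chloro on an aromatic carbon. Within the data shown here, the only measured step that bears on this is a 1.1-fold higher number from compound 2 to compound 3 (0.06 log units; within the scatter), which adds a chloro group to the same ring and is reversed here. Since that step stayed within the scatter, no change beyond the scatter is expected in this assay from compound 3 to compound 4, and the estimated step is a 1.1-fold lower number from compound 3 to compound 4 (0.04 log units; within the scatter). Compound 4 is therefore expected to give about 55000 nM, with a likely range from 25000 nM to 120000 nM.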

Compound 4, half-maximal inhibitory concentration: 38400 nM
Compound 4: the middle estimate sits 1.4-fold (0.16 log units) above what was measured; the range from low to high includes it.
By their numbers in this assay, from the lowest: compounds 4, 2, 3 and 1 (each within the scatter of the next, the first and the last beyond it).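

Taking chloro off this aromatic carbon, ortho to a chloro group, gives a 1.6-fold lower number from compound 3 to compound 4 (0.19 log units; within the scatter) in this assay, so removing this chloro group leaves no change that can be told from the scatter. The earlier compounds shown here showed only the addition of a chloro group to the compound with a single chloro, a 1.1-fold higher number from compound 2 to compound 3 (0.06 log units; within the scatter); together the two steps show that compound 3 cannot be told from either of the compounds that keeps only one of its two chloro groups. Nothing shown accounts for this lack of effect.

Going by these compounds, whether hydrogen and chloro are simply alike at this carbon, or whether a methoxy group, an amine or a carboxylic acid placed there would shift the number beyond the scatter, stays open. The compounds shown also leave open what the shared core gives with no chloro on this ring at all.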